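The compounds below may be only part of what the source reports. "The series", "measured", "known", "first", "only" and "open" are said of these compounds alone.

In a functional assay on the whole organism for antagonist activity, with Mus musculus as the target (a higher number here means that more compound is needed for the effect, a lower number that less compound is needed), compound 3 `CSc1nc(-c2ccccc2)nn1C` gives > 200 mg/kg, which is a limit of the assay and not a number. Compound 1 `Cn1c(-c2cccc(F)c2)nnc1S(C)(=O)=O` also gives only a limit, > 200 mg/kg. Compound 2 `CSc1nnc(-c2cccc(F)c2)n1C` gives only a limit too, > 200 mg/kg. All the readings so far therefore come down to the limit of > 200 mg/kg in this assay, at which 3 of the 3 values shown sit.

Compound 4 `Cn1nc(-c2ccccc2)nc1S(C)(=O)=O` differs from compound 3 by one change, methylsulfonyl in place of methylsulfanyl on an aromatic carbon. Going by the values given here, the one measured step that bears on this is the reverse swap, and it is a step that the two limits leave unreadable from compound 1 to compound 2. It offers no size to carry over, so no clear change is expected. The estimated step is a number no higher from compound 3 to compound 4 (the limit leaves the size open). For compound 4 the expected value is 200 mg/kg, with an estimated range from 100 mg/kg to 400 mg/kg.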

Compound 4, dose for half-maximal effect: > 200 mg/kg
Compound 4 was reported as a limit; the forecaster's own chance of this, stated with the estimate: 85%; the middle value lies on the limit itself.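

No step can be read from compound 3 to compound 4, as each result is a limit of the assay and not a number: the limit of > 200 mg/kg in this assay, at which 4 of the 4 values shown sit.

The compounds shown leave open whether methylsulfonyl in place of methylsulfanyl changes the dose needed, and what dose any of them would need.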